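The source may report more compounds than this note shows. Statements on the series, on what has been measured and on what is new or still open speak of the compounds shown alone.

Measured so far:

Compound 1 `COc1cccc2c1CCC2c1ncc[nH]1` gives > 10000 nM in a functional assay on CHO cells for agonist activity at Alpha-1B adrenergic receptor (Homo sapiens), read by FLIPR and calcium flux (on this read-out higher numbers stand for an effect only at larger amounts of compound and lower numbers for an effect already at smaller amounts), a limit of the assay and not a number.
Compound 2 `CS(=O)(=O)Nc1c(Cl)ccc2c1CCCC2c1ncc[nH]1` gives > 10000 nM in this assay, again only a limit.
Compound 3 `Clc1ccc2c(c1-c1ccn[nH]1)CCC2c1ncc[nH]1` gives > 10000 nM in this assay, likewise a limit.

For the measured compounds named here, compound 1 therefore stands nowhere that can be ranked: its value is a limit, and the two further values shown are limits as well, so no compound in this set can be called more or less active than another. Going by the values given here, the one piece of evidence is the limit of > 10000 nM in this assay, at which 3 of the 3 values shown sit, which places every measurement made so far at the same ceiling.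

The compound still to be measured is compound 4 `c1cc(-c2ncco2)c2c(c1)C(c1ncc[nH]1)CC2`. From compound 1 it differs by 1,3-oxazol-2-yl in place of methoxy on an aromatic carbon; in words, 1,3-oxazol-2-yl in place of methoxy on an aromatic carbon, ortho to a fused ring and meta to a fused ring of the shared core.

Among the compounds with values here, no step between two measured compounds is available, so the size of the change from compound 1 to compound 4 cannot be read from anything measured. The expectation rests only on the three limits: the most likely outcome for compound 4 is a further limit, and the step from compound 1 to compound 4 is expected to be a step that the limit leaves unreadable from compound 1 to compound 4, that is, none that the assay could resolve. Compound 4 is accordingly estimated at 15000 nM, within 3000 nM to 60000 nM.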

Compound 4, half-maximal effective concentration: > 10000 nM
Compound 4: no number, only a limit; the forecaster's own chance of this, stated with the estimate: 75%; the middle value lies beyond the limit too.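

Compound 1 and compound 4 both carry only limits in this assay, so no step between them can be read: the limit of > 10000 nM in this assay, at which 4 of the 4 values shown sit.

The compounds shown leave open whether they differ from one another at all in this assay, and which change to the shared core, if any, would give a readable value.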